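The source may report more compounds than this note shows. Statements on the series, on what has been measured and on what is new or still open speak of the compounds shown alone.

Two compounds sharing one core have been taken through an ADME assay on L02 cells (Homo sapiens) for cytotoxicity, read by MTT assay, with a stated time of 48 h; a higher number here means a weaker inhibitor, a lower number a stronger inhibitor. Compound 1, `O=c1ccoc2cc(OCc3cn(Cc4ccc(F)cc4)nn3)ccc12`, returns only a limit: in this assay compound 1 gives > 300000 nM. Compound 2, `CC(C)(C)c1ccc(Cn2cc(COc3ccc4c(=O)ccoc4c3)nn2)cc1`, likewise returns only a limit: in this assay compound 2 gives > 300000 nM. The step that the two limits leave unreadable from compound 1 to compound 2 therefore cannot be read, because of the limit of > 300000 nM in this assay, at which 2 of the 2 values shown sit. So compound 2 stands at the limit of this assay, with no number of its own.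

Compound 3, `COc1ccc(Cn2cc(COc3ccc4c(=O)ccoc4c3)nn2)cc1`, carries methoxy in place of tert-butyl on an aromatic carbon. Among the compounds with values here, the only measured step that bears on a change at the same aromatic carbon is a step that the two limits leave unreadable from compound 1 to compound 2, and it gives no size, because of the limit of > 300000 nM in this assay, at which 2 of the 2 values shown sit. Within the data shown here, no measured step therefore sets the size or direction of the step in this assay from compound 2 to compound 3; both compounds measured so far give only limits, and a further limit is the likeliest outcome. Compound 3 is therefore expected to give 300000 nM, within 100000 nM to 1000000 nM. The step of a number no higher from compound 2 to compound 3 (the limit leaves the size open) is thus expected to stay within the scatter.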

Compound 3, half-maximal inhibitory concentration: > 300000 nM
Compound 3 gave a limit, no number; the forecaster's own chance of this, stated with the estimate: 85%; the middle value lies on the limit itself.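

Compound 3, like compound 1 and compound 2, yields no readable step in this assay, so the changes among these three compounds cannot be sized, because of a shared ceiling: the limit of > 300000 nM in this assay, at which 3 of the 3 values shown sit.

The compounds shown leave open whether any substituent at this aromatic carbon changes cytotoxicity on these cells.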